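The source may hold more compounds than are shown below. What is called first, only, known or untested is meant among the compounds shown, and "the series" means these compounds.

Compound 1 `COc1cc(-c2nnc(SCC(=O)c3ccccc3)n2N)cc(OC)c1OC`: in a functional assay on HeLa cells (Homo sapiens) for antiproliferative activity, read by MTT assay, with a stated time of 48 h (a lower number here means a stronger inhibitor, a higher number a weaker inhibitor), compound 1 gives > 100000 nM, which is a limit of the assay and not a number.
Compound 2 `COc1cc(-c2nnc(SCC(=O)c3ccc(Br)cc3)n2N)cc(OC)c1OC`: in this assay compound 2 gives 10400 nM.
Compound 3 `COc1cc(-c2nnc(SCC(=O)c3ccc(F)c(F)c3)n2N)cc(OC)c1OC`: in this assay compound 3 gives > 100000 nM, again a limit.

Going by the values given here, compound 2 holds the only number in the set. Compounds 1 and 3 sit at the limit of > 100000 nM in this assay, at which 2 of the 3 values shown sit. Compound 4 `COc1cc(-c2nnc(SCC(=O)NCc3ccc(Cl)cc3)n2N)cc(OC)c1OC` is not yet measured; it differs from compound 2 by (4-chlorobenzyl)amino in place of 4-bromophenyl on a carbonyl carbon. Among the compounds with values here, two measured steps touch the same region of the molecule: an at least 9.6-fold lower number from compound 1 to compound 2 (0.98 log units; beyond the scatter) and an at least 9.6-fold higher number from compound 2 to compound 3 (0.98 log units; beyond the scatter), both at least modest, and both favour the compound carrying the 4-bromophenyl group. Within the data shown here, neither step changes what the carbonyl carbon carries beyond the aromatic ring, so the move to a (4-chlorobenzyl)amino group has no direct precedent here; the loss of the 4-bromophenyl group, the only variant with a number, points toward a higher value. Compound 4 is therefore expected to give 35000 nM, range 6000 nM to 120000 nM, with a real chance of only a limit. The step of a 3.4-fold higher number from compound 2 to compound 4 (0.53 log units; beyond the scatter) is the expected outcome.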

Compound 4, half-maximal inhibitory concentration: > 100000 nM
Compound 4: no number, only a limit (the forecaster's own chance of this, stated with the estimate: 40%); middle value at least 2.8-fold (0.45 log units) from the limit.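

In this assay, going by these compounds alone, the earlier compounds varied only the aromatic ring on the carbonyl carbon, whereas (4-chlorobenzyl)amino on that carbon gives an at least 9.6-fold higher number from compound 2 to compound 4 (0.98 log units; beyond the scatter), so this change does not retain the measurable activity of compound 2. Within the data shown here, compound 2 remains the only compound with a number, and the others all stand at a limit of the assay: the limit of > 100000 nM in this assay, at which 3 of the 4 values shown sit. The steps to compound 4 from compound 1 and from compound 3 join two limits and cannot be read.

The compounds shown do not separate the amino link, the added benzyl carbon and the exchange of bromo for chloro, which all change together in compound 4. On these data alone, how a 4-chlorophenyl or a (4-bromobenzyl)amino group on the carbonyl carbon would read in this assay remains open.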